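Swapping a hydroxy for a nitro on a pyrazole series

The source may hold more compounds than are shown below. What is called first, only, known or untested is meant among the compounds shown, and "the series" means these compounds.

Of the compounds shown here, two sharing one core have been measured in a functional assay on SW-620 cells (Homo sapiens) for inhibition, read by MTT assay, with a stated time of 48 h; a higher number here means a weaker inhibitor of growth, a lower number a stronger inhibitor of growth. Compound 1 `COc1ccc(-c2cc(-c3ccccc3-c3ccccc3)n[nH]2)cc1` gives 890 nM. Within the data shown here, compound 2 `Oc1ccc(-c2cc(-c3ccccc3-c3ccccc3)n[nH]2)cc1` gives 25900 nM, the higher of the two numbers, and so the weaker of the pair; its only neighbour is compound 1, with a step of a 29-fold higher number from compound 1 to compound 2 (1.46 log units; beyond the scatter). Compound 3 `O=[N+]([O-])c1ccc(-c2cc(-c3ccccc3-c3ccccc3)n[nH]2)cc1` has not been measured yet. It differs from compound 2 by nitro in place of hydroxy on an aromatic carbon. Among the measured compounds shown here, no measured step involves a nitro group, so the single step from compound 1 to compound 2 bears on this change only indirectly: it shows that this position is sensitive and that the hydroxy compound is the weakest here. Compound 3 is therefore expected to give a lower number than compound 2, with wide uncertainty, estimated at 6000 nM and plausibly anywhere from 1000 nM to 40000 nM. That estimate corresponds to an expected step of a 4.3-fold lower number from compound 2 to compound 3 (0.64 log units; beyond the scatter).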

Compound 3, concentration for 50% growth inhibition: 12200 nM
Compound 3: middle estimate off by 2.0-fold (0.31 log units), on the low side, within the range that was stated.
By their numbers in this assay, from the lowest: compound 1; then compound 3; then compound 2.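

In this assay, nitro in place of hydroxy gives a 2.1-fold lower number from compound 2 to compound 3 (0.33 log units; beyond the scatter), so the hydroxy compound is not alone in falling well short of the methoxy compound. Nitro in place of methoxy still gives a 14-fold higher number from compound 1 to compound 3 (1.14 log units; beyond the scatter), which leaves compound 1 the strongest of the three and shows that replacing the hydroxy group with just any group does not restore its potency. Nothing available explains why these three groups rank as they do.

From the compounds shown here alone, it remains open how an amine or a carboxylic acid at this place would compare, and whether ethoxy, with its longer chain on the oxygen, would match methoxy. With only one kind of cell represented, it is also unknown whether this order would hold elsewhere.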